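Benzyl for phenyl on the nitrone nitrogen: expectation

The source may report more compounds than this note shows. Statements on the series, on what has been measured and on what is new or still open speak of the compounds shown alone.

Measured compounds:
compound 1 `[O-]/[N+](=C\c1cn(-c2ccccc2)nn1)c1ccccc1`: > 100000 nM
compound 2 `[O-]/[N+](=C\c1cn(-c2ccc(Cl)cc2)nn1)c1ccccc1`: 9700 nM

In a functional assay on COLO 205 cells (Homo sapiens) for inhibition, read by MTT assay, with a stated time of 24 h (a lower number here means a stronger inhibitor, a higher number a weaker inhibitor), compound 1 gives > 100000 nM, which is a limit of the assay and not a number (the limit of > 100000 nM in this assay, at which 1 of the 2 values shown sits). Compound 1 therefore stands at the weak end of the numbers shown, with only a limit to its name. Compound 2 gives 9700 nM. Going by the values given here, the one measured step, an at least 10-fold lower number from compound 1 to compound 2 (1.01 log units; beyond the scatter), is chloro in place of hydrogen on an aromatic carbon.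

Compound 3 `[O-]/[N+](=C\c1cn(-c2ccccc2)nn1)Cc1ccccc1` differs from compound 1 by benzyl in place of phenyl on a double-bonded nitrogen. Among the compounds with values here, no measured step touches this position; the step of an at least 10-fold lower number from compound 1 to compound 2 (1.01 log units; beyond the scatter) changes a different part of the core of compound 1, so it gives no size or direction for the present change. With compound 1 at the limit, a number for compound 3 cannot be grounded on a measured step. Compound 3 is expected at 80000 nM, range 15000 nM to 300000 nM, a step of an at least 1.2-fold lower number from compound 1 to compound 3 (0.09 log units; that floor lies within the scatter) that is an estimate only.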

Compound 3, half-maximal inhibitory concentration: > 100000 nM
Compound 3 gave a limit, no number; the forecaster's own chance of this, stated with the estimate: 55%; middle value at least 1.2-fold (0.09 log units) from the limit.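

In this assay compound 3 gives > 100000 nM as a limit of the assay and not a number. Going by these compounds alone, compound 1 also stands at a limit, so no step between compound 1 and compound 3 can be read: the limit of > 100000 nM in this assay, at which 2 of the 3 values shown sit. The compounds shown leave open whether benzyl in place of phenyl on a double-bonded nitrogen changes the number at all, and in which direction.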